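The source may hold more compounds than are shown below. What is called first, only, known or untested is meant among the compounds shown, and "the series" means these compounds.

Among the compounds with values here, in an ADME assay on HUVEC cells (Homo sapiens) for cytotoxicity, read by MTT assay, with a stated time of 24 h (a lower number here means a stronger inhibitor, a higher number a weaker inhibitor), compound 2, whose structure is `COc1cc(C2Oc3cc(-c4oc5cc(O)cc(O)c5c(=O)c4OC)ccc3OC2CO)ccc1O`, gives 22500 nM, which is the lowest of the three numbers measured so far. Compound 3, `COCC1Oc2ccc(-c3oc4cc(O)cc(O)c4c(=O)c3OC)cc2OC1c1ccc(O)c(OC)c1`, gives 60900 nM, and compound 1, `COc1cc(C2Oc3cc(-c4oc5cc(O)cc(OC)c5c(=O)c4O)ccc3OC2CO)ccc1O`, gives 62400 nM; the two values of compound 1 and compound 3 sit close to each other.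

The compound now in question is compound 4, `COc1cc(O)c2c(=O)c(OC)c(-c3ccc4c(c3)OC(c3ccc(O)c(OC)c3)C(CO)O4)oc2c1`. Compared with compound 2 the change is methyl in place of hydrogen on an oxygen on an aromatic ring. Within the data shown here, no measured pair shows exactly this change. The closest comparison is the step of a 2.7-fold higher number from compound 2 to compound 3 (0.43 log units; beyond the scatter), which adds a methyl to an oxygen as well, though there on a saturated carbon rather than on an aromatic ring. Compound 1 cannot be used as a clean guide, since it differs from compound 2 in two places; its value only shows that a rearrangement of hydroxy and methoxy groups on the aromatic part goes together with a higher number.

Taking the step from compound 2 to compound 3 as the nearest precedent, a modest rise of similar size is expected, and the step of a 2.0-fold higher number from compound 2 to compound 4 (0.30 log units; within the scatter) is the estimated outcome. Compound 4 is therefore expected to give about 45000 nM in this assay, with a plausible range from 15000 nM to 130000 nM.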

Compound 4, half-maximal inhibitory concentration: 43100 nM
For compound 4 the middle estimate is 1.0-fold (0.02 log units) above the measured one; the measured number falls inside the stated range.
By their numbers in this assay, from the lowest: compounds 2, 4, 3 and 1 (each within the scatter of the next, the first and the last beyond it).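

In this assay, within the data shown here, this is the first clean look at hydroxy to methoxy on an oxygen on an aromatic ring, and it gives a 1.9-fold higher number from compound 2 to compound 4 (0.28 log units; within the scatter), so adding this methyl leaves the two compounds indistinguishable in this measurement. The earlier step, a 2.7-fold higher number from compound 2 to compound 3 (0.43 log units; beyond the scatter), also placed a methyl on an oxygen, but on a saturated carbon, and that step lies beyond the usual scatter, so the same small addition is not read alike at these two places, with one pair of compounds standing behind each. Nothing measured here gives a reason for this contrast.

A single pair speaks for only one oxygen, so the other hydroxy groups on aromatic rings in the shared core could respond differently to the same methyl. Going by these compounds, it also remains open whether a longer chain such as ethyl, or an amine in place of the hydroxy, would stay as close to compound 2 as the methoxy of compound 4 does.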